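The source may hold more compounds than are shown below. What is called first, only, known or untested is meant among the compounds shown, and "the series" means these compounds.

Measured compounds and their half-lives in mice:

compound 1, `C[C@H]1NC(=O)CNC(=O)[C@H](CCCN=C(N)N)NC(=O)[C@H](Cc2ccc(O)cc2)NC1=O`: 1 h
compound 2, `N=C(N)NCCC[C@@H]1NC(=O)[C@H](Cc2ccc(O)cc2)NC(=O)[C@@H](Cc2ccc(Cl)cc2)NC(=O)CNC1=O`: > 1.5 h

In an ADME assay on the whole organism with Mus musculus as the target (on this read-out lower numbers stand for a shorter-lived compound and higher numbers for a longer-lived compound), compound 1 gives 1 h. Compound 2 reaches only a limit of this assay rather than a number: in this assay compound 2 gives > 1.5 h. For the measured compounds named here, this is the upper bound described by the limit of > 1.5 h in this assay, at which 1 of the 2 values shown sits, so where compound 2 actually stands above that bound is not known, and the two measured compounds differ in more than one place, so no single step between them can be read from their values.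

Compound 3, `N=C(N)NCCC[C@@H]1NC(=O)[C@H](Cc2ccc(O)cc2)NC(=O)[C@@H](Cc2ccc(N)cc2)NC(=O)CNC1=O`, is the next compound to be measured in this assay. It differs from compound 2 by one exchange: amino in place of chloro on an aromatic carbon. Going by the values given here, no step between measured compounds resembles this exchange, so there is nothing to scale the expectation against.

Compound 3 is therefore expected to stay close to compound 2, with a step from compound 2 to compound 3 of a number no higher from compound 2 to compound 3 (the limit leaves the size open), which is expected to lie within the scatter rather than beyond it. For compound 3 in this assay a half-life of about 1.5 h is estimated, with a range from 0.7 h to 3.2 h.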

Compound 3, half-life: 1 h
Compound 3: the middle estimate sits 1.5-fold (0.18 log units) above what was measured, and the stated range covers the measured number.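

In this assay, for the compounds shown here, amino in place of chloro on an aromatic carbon, para to a large group, gives the first step that can be read at this position: an at least 1.5-fold lower number from compound 2 to compound 3 (0.17 log units; that floor lies within the scatter). For compound 2 the value > 1.5 h is a limit of the assay and not a number. The printed step is therefore only a floor, and the true size of the change remains unknown and could lie beyond the scatter, because the starting point of the step is a limit rather than a number: the limit of > 1.5 h in this assay, at which 1 of the 3 values shown sits.

The compounds shown leave open how a hydroxyl, a methoxy group or a carboxylic acid on the same aromatic carbon would compare with chloro and amino, and whether any difference would lie beyond the scatter. Going by these compounds, compound 1 is joined to neither of the other two by a single step, so it also remains open how the 4-chlorobenzyl or 4-aminobenzyl group on its own compares with a plain benzyl group or a methyl group on the shared core.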